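Removing a side chain from an adenosine binder

The source may hold more compounds than are shown below. What is called first, only, known or untested is meant among the compounds shown, and "the series" means these compounds.

Three compounds sharing one core were tested in an assay on CHO cells for displacement of a labelled ligand from adenosine receptor A3 (Homo sapiens), read by scintillation counting, tested at 10 uM; a lower number here means less inhibition, a higher number more inhibition at the concentration tested (going by the name of the read-out). Compound 1 `CC(C)(C)Cc1c(-c2ccccn2)sc(N)c1C(=O)c1ccc(Cl)cc1` gives 1%. Compound 2 `CC(C)(C)Cc1c(/C=C/c2ccc(Cl)cc2)sc(N)c1C(=O)c1ccc(Cl)cc1` gives 11%, a step of a number 10 percentage points higher from compound 1 to compound 2 (within the scatter). Compound 3 `COCCOc1ccc(-c2sc(N)c(C(=O)c3ccc(Cl)cc3)c2CC(C)(C)C)cc1` gives 1%, level with compound 1 at the digits shown and, together with it, the lowest of the three numbers; its gap to compound 2 lies within the scatter, so none of the three can be called stronger or weaker than another.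

Compound 4 `CC(C)(C)Cc1c(-c2ccccc2)sc(N)c1C(=O)c1ccc(Cl)cc1` has not yet been measured. It differs from compound 3 in one place: hydrogen in place of 2-methoxyethoxy on an aromatic carbon. Among the compounds with values here, no measured pair shows this exact change. Within the data shown here, the only recorded step, from compound 1 to compound 2, also swaps the group attached to an aromatic carbon, and it stays within the scatter. With all three measured numbers low and no step beyond the scatter, the expected step is a number 1 percentage points higher from compound 3 to compound 4 (within the scatter), meaning no movement beyond the usual scatter. Compound 4 is therefore estimated at 2%, with a range from -8% to 12%.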

Compound 4, a percentage reported as inhibition, at one concentration (the size of the read-out at that concentration, not a potency): 1%
The estimate for compound 4 lay 1 percentage points above the measured number; low and high end bracket the measured number.
By their numbers in this assay, from the lowest: compounds 1, 3, 4 and 2 (each within the scatter of the next).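

In this assay the change gives no change at the digits printed from compound 3 to compound 4 (within the scatter) when the 2-methoxyethoxy on the aromatic carbon para to a large group gives way to hydrogen, so this side chain makes no readable difference at this position. The plain phenyl also sits level within the scatter with the two other groups tested on the shared core, with no change at the digits printed from compound 1 to compound 4 (within the scatter) for phenyl in place of pyridin-2-yl and a number 10 percentage points lower from compound 2 to compound 4 (within the scatter) for phenyl in place of 2-(4-chlorophenyl)ethenyl. Within the data shown here, no group at this place so far stands apart from another, and the bare ring reads the same as the ring carrying the chain.

Going by these compounds, whether an amine or a carboxylic acid at that same place on the phenyl would move the number beyond the scatter stays open, as does the effect of changes elsewhere on the shared core. No measurement at hand gives a reason for these readings.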